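The source may hold more compounds than are shown below. What is called first, only, known or untested is meant among the compounds shown, and "the series" means these compounds.

Of the compounds shown here, three share one core and have been measured in an ADME assay on microsomes from liver (Homo sapiens) for metabolic stability, read by LC-MS, using NADPH, tested at 5 uM; a lower number here means that the compound disappears faster, a higher number that the compound lasts longer. Compound 1 `NS(=O)(=O)c1cc(-c2nnc(CN3CCC(Cc4ccccc4)CC3)o2)c(Cl)cc1SCc1ccccc1` gives 0.363 h. Compound 3 `NS(=O)(=O)c1cc(-c2nnc(/C=C/c3ccccc3)o2)c(Cl)cc1SCc1ccccc1` gives 0.228 h. Compound 2 `CCOC(=O)c1cn(Cc2nnc(-c3cc(S(N)(=O)=O)c(SCc4ccccc4)cc3Cl)o2)nn1` gives 0.085 h, the lowest of the three numbers, with compound 3 nearest and compound 1 furthest from it, both beyond the scatter.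

Compound 4 `NS(=O)(=O)c1cc(-c2nnc(/C=C/c3c(Cl)cccc3Cl)o2)c(Cl)cc1SCc1ccccc1` has not yet been measured. Its structure differs from compound 2 in one place: 2-(2,6-dichlorophenyl)ethenyl in place of (4-(ethoxycarbonyl)-1H-1,2,3-triazol-1-yl)methyl on an aromatic carbon.

Going by the values given here, one measured step bears directly on this change. Replacing the same (4-(ethoxycarbonyl)-1H-1,2,3-triazol-1-yl)methyl group with 2-phenylethenyl gave a 2.7-fold higher number from compound 2 to compound 3 (0.43 log units; beyond the scatter). Among the compounds with values here, compound 4 carries a 2-(2,6-dichlorophenyl)ethenyl group instead, and no measured pair shows what adding the two chlorine atoms does on its own; the value of compound 3 is the only point of reference for that part of the change.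

A step of about the same size and direction is therefore expected, from compound 2 to compound 4, a 3.3-fold higher number from compound 2 to compound 4 (0.52 log units; beyond the scatter). For compound 4 a half-life of about 0.28 h is estimated in this assay, expected to fall between 0.14 h and 0.56 h.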

Compound 4, half-life: 0.468 h
Compound 4: middle estimate off by 1.7-fold (0.22 log units), on the low side; the measured number falls inside the stated range.
By their numbers in this assay, from the lowest: compound 2; then compounds 3, 1 and 4 (each within the scatter of the next, the first and the last beyond it).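

The chlorine atoms can now be read on their own in this assay: 2,6-dichlorophenyl in place of phenyl on the double-bonded chain gives a 2.1-fold higher number from compound 3 to compound 4 (0.31 log units; beyond the scatter) and so adds to what the chain with plain phenyl had already achieved. Measured against the group bearing the triazole and the ethyl ester, this position now shows a 5.5-fold higher number from compound 2 to compound 4 (0.74 log units; beyond the scatter) in place of the earlier 2.7-fold higher number from compound 2 to compound 3 (0.43 log units; beyond the scatter) as the full change, so on this aromatic carbon of the five-membered ring the half-life responds to substitution on the far phenyl ring as well as to the swap of the whole group. Nothing available explains why the compound with the two chlorine atoms lasts longer.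

From the compounds shown here alone, whether fluorine, methyl or methoxy in place of the chlorine atoms would move the half-life in the same direction remains open. Going by these compounds, it is equally open what an amine on the phenyl ring would do, or a longer chain between the phenyl ring and the five-membered ring.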